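Changing the Halogen Pattern on the Amine-Borne Phenyl

The source may hold more compounds than are shown below. What is called first, only, known or untested is meant among the compounds shown, and "the series" means these compounds.

Of the compounds shown here, three built on one shared core have been tested in an assay on CHO cells for displacement of a labelled ligand from adenosine receptor A1 (Homo sapiens), read by scintillation counting, with a stated time of 120 min, tested at 10 uM; a lower number here means less inhibition, a higher number more inhibition at the concentration tested (going by the name of the read-out). Compound 1 `Nc1scc(CN2CCN(c3cccc(Cl)c3Cl)CC2)c1C(=O)c1ccc(Cl)cc1` gives 2%, the highest of the three numbers shown, although all three lie within the scatter of one another. Compound 2 `COc1ccc(N2CCN(Cc3csc(N)c3C(=O)c3ccc(Cl)cc3)CC2)cc1` gives 0%, and compound 3 `Nc1scc(CN2CCN(c3cccc(F)c3F)CC2)c1C(=O)c1ccc(Cl)cc1` gives 0%. The steps of a number 2 percentage points lower from compound 1 to compound 2 (within the scatter) and a number 2 percentage points lower from compound 1 to compound 3 (within the scatter) show that exchanging the aryl group on the ring nitrogen has so far produced nothing beyond the scatter. Compound 4 `Nc1scc(CN2CCN(c3ccc(F)c(Cl)c3)CC2)c1C(=O)c1ccc(Cl)cc1` differs from compound 1 by 3-chloro-4-fluorophenyl in place of 2,3-dichlorophenyl on an amine nitrogen in a ring. Both earlier steps bear on this change and both stayed within the scatter, so no step beyond the scatter is expected: the estimated step is a number 1 percentage points lower from compound 1 to compound 4 (within the scatter). Compound 4 is therefore estimated at 1%, with an expected range from 0% to 9%.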

Compound 4, a percentage reported as inhibition, at one concentration (the size of the read-out at that concentration, not a potency): 0%
The estimate for compound 4 lay 1 percentage points above the measured number; measured number inside the range.
By their numbers in this assay, from the lowest: compounds 2, 3, 4 and 1 (each within the scatter of the next).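

In this assay the step of a number 2 percentage points lower from compound 1 to compound 4 (within the scatter) stays small, as do the step of no change at the digits printed from compound 3 to compound 4 (within the scatter) and the step of no change at the digits printed from compound 2 to compound 4 (within the scatter) when chlorine and fluorine are combined on one phenyl ring. This mixed halogen pattern therefore separates from none of the other three aryl groups on this amine nitrogen. Nothing measured here offers an explanation for this result.

On these data alone, whether any group at this place can raise the number beyond the scatter remains open. A phenyl ring bearing a carboxylic acid or an amine, or a benzyl group, could test this.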